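The source may report more compounds than this note shows. Statements on the series, on what has been measured and on what is new or still open speak of the compounds shown alone.

Of the compounds shown here, three built on one shared core have been tested in a functional assay on A549 cells (Homo sapiens) for inhibition, read by MTT assay, with a stated time of 72 h; on this read-out lower numbers stand for stronger inhibition and higher numbers for weaker inhibition. Compound 1 `O=C(CCC(=O)OCCCCCCSc1ccc([N+](=O)[O-])c2nonc12)Nc1cccc(Cl)c1` gives 5290 nM, compound 2 `O=C(CCC(=O)OCCCCCCSc1ccc([N+](=O)[O-])c2nonc12)Nc1ccc(Br)cc1` gives 3340 nM, and compound 3 `COc1ccc(NC(=O)CCC(=O)OCCCCCCSc2ccc([N+](=O)[O-])c3nonc23)cc1` gives 6480 nM. Compound 2 has the lowest number of the three, yet the steps of a 1.6-fold lower number from compound 1 to compound 2 (0.20 log units; within the scatter) and a 1.9-fold higher number from compound 2 to compound 3 (0.29 log units; within the scatter) are both within the scatter, as is a 1.2-fold higher number from compound 1 to compound 3 (0.09 log units; within the scatter), so the three compounds cannot be told apart by this read-out.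

Compound 4 `O=C(CCC(=O)OCCCCCCSc1ccc([N+](=O)[O-])c2nonc12)NCCN1CCCC1` has not been measured. It differs from compound 2 in one place: 2-(pyrrolidin-1-yl)ethyl in place of 4-bromophenyl on an amide-type nitrogen. The group on the amide-type nitrogen is no longer a six-membered aromatic ring of carbon only but a 2-(pyrrolidin-1-yl)ethyl chain carrying a five-membered non-aromatic ring with 1 hetero atom.

Every measured step exchanges one substituted aromatic ring for another on that same nitrogen, and each stays within the scatter. None exchanges the aromatic ring for a chain of this kind, so they give only weak guidance: small changes at that position barely moved the number, while a larger change could move it either way. Compound 4 is expected to give 6000 nM, within 2000 nM to 20000 nM. The expected step is a 1.8-fold higher number from compound 2 to compound 4 (0.25 log units; within the scatter), leaning toward a somewhat higher number with wide uncertainty.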

Compound 4, half-maximal inhibitory concentration: 3240 nM
The estimate for compound 4 lay 1.9-fold (0.27 log units) above the measured number; measured number inside the range.
By their numbers in this assay, from the lowest: compounds 4, 2, 1 and 3 (each within the scatter of the next).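

In this assay, for the compounds shown here, the earlier compounds only exchanged one substituted aromatic ring for another on the amide-type nitrogen, whereas compound 4 carries no aromatic ring there, and the steps of a 1.0-fold lower number from compound 2 to compound 4 (0.01 log units; within the scatter) and a 1.6-fold lower number from compound 1 to compound 4 (0.21 log units; within the scatter) and a 2.0-fold lower number from compound 3 to compound 4 (0.30 log units; within the scatter) all stay within the scatter. Among these four compounds, then, a six-membered aromatic ring of carbon only is not required on this nitrogen for a number in this range, since 2-(pyrrolidin-1-yl)ethyl, a chain ending in a five-membered non-aromatic ring with 1 hetero atom, cannot be told apart from the three aromatic groups by this read-out. No measurement offered here accounts for how little the number responds to so large an exchange.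

On these data alone, whether any group on this nitrogen can move the number beyond the scatter remains open, for example a carboxylic acid, an open-chain amine such as 2-(dimethylamino)ethyl, or a longer chain ending in pyrrolidine. All four compounds share the rest of the structure, so they say nothing about how the number would respond to a change elsewhere in the shared core.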